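The source may hold more compounds than are shown below. What is called first, only, known or untested is meant among the compounds shown, and "the series" means these compounds.

Notes on the series. an assay for inhibition of HSP60/HSP10 (Homo sapiens), with a stated time of 60 min (a lower number here means a stronger inhibitor, a higher number a weaker inhibitor), is the only read-out here. Compound 1 `COc1ccccc1C(=O)Nc1ccc(Sc2nc3ccccc3s2)cc1` gives > 100000 nM, and that figure is a limit of the assay rather than a number (the limit of > 100000 nM in this assay, at which 1 of the 3 values shown sits). Compound 2 `O=C(Nc1cccc(Cl)c1)c1cc(Br)cc(Br)c1O` gives 29000 nM, and compound 3 `O=C(Nc1ccccc1)c1cc(Br)cc(Br)c1O` gives 63000 nM. Among the two numbers that are not limits, compound 2 stands lowest; the step from it is a 2.2-fold higher number from compound 2 to compound 3 (0.34 log units; beyond the scatter), a modest move on swapping chloro for hydrogen on an aromatic carbon.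

The next compound, compound 4 `O=C(Nc1cccc(Cl)c1)c1cc(Br)cc(Br)c1`, keeps everything of compound 2 except one change: hydrogen in place of hydroxy on an aromatic carbon. The hydroxy sits on an aromatic carbon of the six-membered carbon-only ring, ortho to a bromo group and ortho to a large group, and para to a bromo group.

Within the data shown here, no measured step touches the hydroxy; the only measured step is the chloro-to-hydrogen swap on the other ring, and it was modest. There is thus nothing here to size the hydroxy removal from, and the direction can only be guessed. The working expectation is a weaker compound 4, with the step of a 2.4-fold higher number from compound 2 to compound 4 (0.38 log units; beyond the scatter) estimated as a higher number, possibly running into the assay limit. Compound 4 is estimated at 70000 nM in this assay, within 20000 nM to 250000 nM.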

Compound 4, half-maximal inhibitory concentration: > 100000 nM
Compound 4: only a limit was reported; the forecaster's own chance of this, stated with the estimate: 45%; middle value at least 1.4-fold (0.15 log units) from the limit.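

Hydrogen in place of hydroxy on this aromatic carbon, ortho to a bromo group and ortho to a large group, gives an at least 3.4-fold higher number from compound 2 to compound 4 (0.53 log units; beyond the scatter) in this assay. Among these compounds, this is the first measured change at this position, and it shows that the hydroxy cannot be dropped from compound 2 without a loss beyond the scatter, whereas the only earlier step, on the other ring, concerned the chloro group. Compound 4 gives > 100000 nM, which is a limit of the assay and not a number, so the step fixes a direction and a minimum size only, since the reading stops where other compounds in the series also stop: the limit of > 100000 nM in this assay, at which 2 of the 4 values shown sit.

The compounds shown leave open whether the hydroxy itself is needed or whether another group on this carbon, such as a methoxy or an amine, would keep a measurable number in this assay. They also leave open how far the same removal would carry on the background of compound 3, without the chloro group, and what either bromo group contributes.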